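The compounds below may be only part of what the source reports. "The series", "measured", "known", "first", "only" and "open" are said of these compounds alone.

Of the compounds shown here, two have been measured, and a third awaits its turn. Compound 1 `COc1cc(O)c(C(=O)/C=C/c2ccc(F)cc2)c(OC)c1` and compound 2 `COc1cc(OC)c(C(=O)/C=C/c2ccccc2SC)c(OC)c1` share a core built around a carbonyl joined to a two-carbon chain with one double bond, which carries an aromatic ring at its far end. In a functional assay on PC-3 cells (Homo sapiens), read by fluorescence and BrdU incorporation, with a stated time of 48 h, tested at 10 uM (a higher number here means a weaker effect of the compound at the concentration tested, a lower number a stronger effect), compound 1 gives 37%, and compound 2 gives 30%. The gap between these two numbers lies within the scatter of the measurement, so compound 2 stands alongside compound 1 and neither can be called the stronger or the weaker of the pair.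

Compound 3 `COc1cccc(/C=C/C(=O)c2c(OC)cc(OC)cc2OC)c1` differs from compound 2 in one place: 3-methoxyphenyl in place of 2-(methylsulfanyl)phenyl on a double-bonded chain carbon bound to a double-bonded chain carbon. Going by the values given here, no measured step of exactly this kind exists among the two compounds already in hand, so there is nothing to say how large a difference such a swap of ring makes. With only the two neighbouring numbers to lean on, the change from compound 2 to compound 3 is expected to amount to a step of a number 3 percentage points higher from compound 2 to compound 3 (within the scatter) in this assay, that is, none beyond the scatter. Compound 3 is therefore estimated at 33%, with a range from 18% to 50%.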

Compound 3, a percentage reported as activity, at one concentration (the size of the read-out at that concentration, not a potency): 23%
For compound 3 the middle estimate is 10 percentage points above the measured one; the measured number falls inside the stated range.
By their numbers in this assay, from the lowest: compounds 3, 2 and 1 (each within the scatter of the next, the first and the last beyond it).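

In this assay, going by these compounds alone, putting 3-methoxyphenyl in place of 2-(methylsulfanyl)phenyl on a double-bonded chain carbon bound to a double-bonded chain carbon gives the first step that can be read at this position: a number 7 percentage points lower from compound 2 to compound 3 (within the scatter). Both groups have 8 heavy atoms and one six-membered aromatic ring, so this exchange of sulfur for oxygen, at a similar group size, leaves the read-out with no difference beyond the scatter; however, the two names also differ in the number that places the group on the ring, and this single step cannot separate that from the change of atom. Nothing in hand explains the size of this step.

From the compounds shown here alone, a 2-methoxyphenyl or a 3-(methylsulfanyl)phenyl group in the same place would help to pull those two changes apart, and how either would read remains open. Also open, going by these compounds, is whether a ring carrying an amine or a carboxylic acid there would move the number beyond the scatter, in either direction.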